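The compounds below may be only part of what the source reports. "The series", "measured", "known", "first", "only" and "open" are said of these compounds alone.

Within the data shown here, compound 3 `CCOc1ncc(-c2nc(C(F)(F)F)sc2N2CCN(C(=O)Cn3c(=O)oc4ccccc43)[C@H](C)C2)cn1` gives 536 nM in an assay on blood for inhibition of C-X-C chemokine receptor type 3 (Homo sapiens), with a stated time of 30 min (a lower number here means a stronger inhibitor, a higher number a weaker inhibitor), and has the lowest of the three numbers measured so far, though its gap to compound 1 `C[C@@H]1CN(c2scnc2-c2nc3ccccc3[nH]2)CCN1C(=O)Cn1cnc2cccnc21` is within the scatter: compound 1 gives 554 nM in this assay. Compound 2 `C[C@@H]1CN(c2sc(CN(C)C)nc2-c2nc3ccccc3[nH]2)CCN1C(=O)Cn1cnc2cccnc21` gives 1150 nM in this assay; the step from compound 1 to compound 2 is a 2.1-fold higher number from compound 1 to compound 2 (0.32 log units; beyond the scatter) and arises from (dimethylamino)methyl in place of hydrogen on an aromatic carbon.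

Compound 4 `CCOc1ncc(-c2nc(C(F)(F)F)sc2N2CCN(C(=O)Cn3cnc(C(F)(F)F)n3)[C@H](C)C2)cn1` is not yet measured in this assay. It differs from compound 3 in the group on a saturated chain carbon bound to a carbonyl carbon: a group of 9 heavy atoms (3 carbon, 3 nitrogen, 3 fluorine; one five-membered aromatic ring with 3 hetero atoms) in place of a group of 10 heavy atoms (7 carbon, 1 nitrogen, 2 oxygen; one five-membered aromatic ring with 2 hetero atoms, one six-membered aromatic ring of carbon only), on a saturated chain carbon bound to a carbonyl carbon. Among the measured compounds shown here, none of the measured steps changes this part of the shared core; the only measured step concerns a substituent on an aromatic carbon elsewhere, so it gives no direct guide here. Any direction is therefore open, and the expected step from compound 3 to compound 4 is a 1.1-fold higher number from compound 3 to compound 4 (0.05 log units; within the scatter), set near no change with a wide range. Compound 4 is expected to give 600 nM in this assay, estimated between 150 nM and 2500 nM.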

Compound 4, half-maximal inhibitory concentration: 524 nM
Compound 4: the middle estimate sits 1.1-fold (0.06 log units) above what was measured; low and high end bracket the measured number.
By their numbers in this assay, from the lowest: compounds 4, 3 and 1 (each within the scatter of the next); then compound 2.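

In this assay, the saturated chain carbon bound to a carbonyl carbon accepts 3-(trifluoromethyl)-1H-1,2,4-triazol-1-yl in place of the group with a five-membered and a six-membered aromatic ring, with a 1.0-fold lower number from compound 3 to compound 4 (0.01 log units; within the scatter). Among these compounds, this is the first step read at this position, and removing the six-membered aromatic ring of carbon only leaves the number within the scatter, so in this pair that ring is not required to hold the value. No measurement at hand offers an explanation for this result.

From the compounds shown here alone, it remains open whether this position tolerates groups other than these two aromatic ones, which an amine or a carboxylic acid on the same chain carbon would test. Also open, going by these compounds, is what the trifluoromethyl contributes, which the unsubstituted 1H-1,2,4-triazol-1-yl group would show.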